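Fluoro on the pyridyl ring: expected effect on antagonist potency

The source may hold more compounds than are shown below. What is called first, only, known or untested is meant among the compounds shown, and "the series" means these compounds.

In an in vitro functional assay on HEK285-7 cells for antagonist activity at prostaglandin D2 receptor 2 (Homo sapiens), read by BRET and beta-arrestin recruitment (on this read-out lower numbers stand for stronger inhibition and higher numbers for weaker inhibition), compound 1 `O=C(O)Cc1sc(C(c2ccccc2)c2ccc(F)cc2)nc1-c1ccc(Cl)cc1` gives 36 nM. Compound 2 `O=C(O)Cc1sc(C(c2ccc(F)cc2)c2ccc(F)cc2)nc1-c1ccc(Cl)cc1` carries the change (fluoro in place of hydrogen on an aromatic carbon), and in this assay compound 2 gives 180 nM, a step of a 5.0-fold higher number from compound 1 to compound 2 (0.70 log units; beyond the scatter). Compound 3 `O=C(O)Cc1sc(C(c2ccc(F)cc2)c2ccc(F)cc2)nc1-c1ccncc1` gives 40 nM in this assay; the difference between its core and that of compound 1 is not broken down here, while the step of a 4.5-fold lower number from compound 2 to compound 3 (0.65 log units; beyond the scatter) separates compound 3 from compound 2. Compound 4 `O=C(O)Cc1sc(C(c2ccc(F)cc2)c2ccc(F)cc2)nc1-c1ccnc(F)c1` differs from compound 3 by fluoro in place of hydrogen on an aromatic carbon, the same kind of change as from compound 1 to compound 2, though the place is not identical: there on a ring of carbon only, para to a large group; here on a ring with one nitrogen, next to the ring nitrogen, meta to a large group. Because a 5.0-fold higher number from compound 1 to compound 2 (0.70 log units; beyond the scatter) weakened inhibition, compound 4 is expected to show a smaller loss, estimated as a 2.5-fold higher number from compound 3 to compound 4 (0.40 log units; beyond the scatter). Compound 4 is therefore estimated at 100 nM, between 40 nM and 300 nM.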

Compound 4, half-maximal inhibitory concentration: 4.7 nM
The estimate for compound 4 lay 21-fold (1.33 log units) above the measured number; the measured number lies below the stated range.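

In this assay, pyridin-4-yl to 2-fluoropyridin-4-yl gave an 8.5-fold lower number from compound 3 to compound 4 (0.93 log units; beyond the scatter), and 2-fluoropyridin-4-yl in place of 4-chlorophenyl gave a 38-fold lower number from compound 2 to compound 4 (1.58 log units; beyond the scatter). Fluoro in place of hydrogen on an aromatic carbon therefore did not carry over as one fixed effect in this series, as the two steps ran in opposite directions: the same change on two cores in this assay, a 5.0-fold higher number (0.70 log units; beyond the scatter) from compound 1 to compound 2 and an 8.5-fold lower number (0.93 log units; beyond the scatter) from compound 3 to compound 4, 43-fold (1.63 log units) apart, beyond the scatter of two such steps The two steps differ in both the core and the place of the fluoro, and this single pair of steps does not show which of these separates them.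

The compounds shown leave open whether a chloro or a methyl group next to the ring nitrogen would act as fluoro does. They also leave open whether a methoxy group there would do so.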